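Cytotoxicity limit and a larger ether on the shared core

The source may hold more compounds than are shown below. What is called first, only, known or untested is meant among the compounds shown, and "the series" means these compounds.

Measured in an ADME assay on KB cells (Homo sapiens) for cytotoxicity; a lower number here means that less compound is needed, a higher number that more compound is needed for the effect:
- Compound 1 `CCOC(=O)N1[C@@H]2C=C[C@@](OC)(C(=O)c3c2cc(OC)c(OC)c3OCC)N1C(=O)OCC`: > 300 ug/mL
- Compound 2 `CCOc1c(OC)c(OC)cc2c1C(=O)[C@]1(OC)C=C[C@H]2N(C(=O)OCC(C)C)N1C(=O)OCC(C)C`: > 300 ug/mL

Compound 2 gives > 300 ug/mL, which is a limit and not a number. Compound 1 gives > 300 ug/mL, which is also a limit. Together they define the evidence so far: the limit of > 300 ug/mL in this assay, at which 2 of the 2 values shown sit.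

Compound 3 `COc1cc2c(c(OCc3ccccc3)c1OC)C(=O)[C@]1(OC)C=C[C@H]2N(C(=O)OCC(C)C)N1C(=O)OCC(C)C` departs from compound 2 in one place: phenyl in place of methyl on a saturated chain carbon bound to an oxygen on an aromatic ring. This puts phenyl in place of methyl on a saturated chain carbon bound to an oxygen on an aromatic ring, turning ethoxy into benzyloxy.

Neither measured compound supplies a number, so the size of a step cannot be read from them. In this assay, no step beyond the scatter is expected, and any shift would more likely be toward a lower number. The expected step is a number no higher from compound 2 to compound 3 (the limit leaves the size open). For compound 3 the estimated value is 300 ug/mL, with an expected range from 100 ug/mL to 600 ug/mL.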

Compound 3, concentration for half-maximal effect: 94 ug/mL
Compound 3: the middle estimate sits 3.2-fold (0.50 log units) above what was measured; the measured number lies below the stated range.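

In this assay, the oxygen on the aromatic ring proves to be a place where a single change registers: phenyl in place of methyl on the saturated chain carbon bound to it, turning ethoxy into benzyloxy, gives an at least 3.1-fold lower number from compound 2 to compound 3 (0.50 log units; beyond the scatter). Compound 3 is therefore the only one of the three shown that carries a number instead of a limit, and the earlier compounds gave no sign that any change on this core could do so. The step can be stated only as a lower bound, because its starting point is a limit: the limit of > 300 ug/mL in this assay, at which 2 of the 3 values shown sit.

Going by these compounds, it remains open whether the phenyl ring is what counts, or whether a longer chain such as propoxy on the same oxygen would do the same. Also open, on these data alone, is whether benzyloxy would lower the number on the core of compound 1.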